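Varying the amine substituent on the shared core: compound 3

The compounds below may be only part of what the source reports. "The series", "measured", "known", "first", "only" and "open" are said of these compounds alone.

Measured in a functional assay on MDA-MB-435 cells (Homo sapiens) for cytotoxicity, read by MTT assay, with a stated time of 72 h; on this read-out higher numbers stand for weaker inhibition and lower numbers for stronger inhibition:
compound 1 `Nc1ccc(Nc2c(C(=O)NCc3ccc(F)cc3)nc(Br)c3cccnc23)cc1` — 7000 nM
compound 2 `O=C(NCc1ccc(F)cc1)c1nc(Br)c2cccnc2c1NCc1ccc(F)cc1` — > 20000 nM

Compound 2 stands at the limit of this assay, so its value is a limit and not a number (the limit of > 20000 nM in this assay, at which 1 of the 2 values shown sits). Going by the values given here, the only measured step, an at least 2.8-fold higher number from compound 1 to compound 2 (0.45 log units; beyond the scatter), concerns the same nitrogen on the aromatic ring, where 4-fluorobenzyl in place of 4-aminophenyl gave the weaker compound 2.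

Compound 3 `O=C(NCc1ccc(F)cc1)c1nc(Br)c2cccnc2c1NCCO` keeps the 4-fluorobenzyl amide and the bromine of compound 2 and alters the substituent on that nitrogen: hydroxymethyl in place of 4-fluorophenyl on a saturated chain carbon bound to a nitrogen on an aromatic ring. Among the compounds with values here, no measured step tests this kind of change, so no size or direction can be read from the data; the step from compound 1 to compound 2 shows only that this position is sensitive.

Since compound 2 already sits at the limit, compound 3 is expected most likely to report a limit as well, with a step that the limit leaves unreadable from compound 2 to compound 3 as the estimated step. In this assay compound 3 is expected to give about 30000 nM, in the range 8000 nM to 100000 nM.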

Compound 3, half-maximal inhibitory concentration: > 20000 nM
Compound 3 gave a limit, no number; the forecaster's own chance of this, stated with the estimate: 70%; the middle value lies beyond the limit too.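

In this assay compound 3 gives > 20000 nM, which is a limit and not a number. Replacing 4-aminophenyl with 2-hydroxyethyl on the nitrogen gives an at least 2.8-fold higher number from compound 1 to compound 3 (0.45 log units; beyond the scatter), so a second and very different substituent, with no ring and with a hydrogen-bond donor, also falls beyond the scatter from compound 1, as 4-fluorobenzyl did in an at least 2.8-fold higher number from compound 1 to compound 2 (0.45 log units; beyond the scatter). Among the three compounds, only the 4-aminophenyl of compound 1 gives a number, while the step from compound 2 to compound 3 cannot be read, and neither compound can be ranked against the other at the shared limit: the limit of > 20000 nM in this assay, at which 2 of the 3 values shown sit.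

The compounds shown leave open whether a plain phenyl on that nitrogen, without the amino group, would stay near compound 1 or reach the limit. They also leave open whether a 2-aminoethyl chain, or a longer chain ending in a hydroxyl, would give a number or join compound 3 at the limit.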